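Working notes: from compound 3 to compound 4

The compounds below may be only part of what the source reports. "The series", "measured", "known", "first", "only" and "open" are said of these compounds alone.

In a physicochemical assay for lipophilicity, using the shake flask method, measured as octanol-water partition, at pH 7.4 (a lower number here means a more polar compound, a higher number a more lipophilic compound), compound 3 (`CC(=O)N[C@@H]1CCC[C@H](C(=O)Nc2cc(-c3cnn4c3CCCCC4)c(Cl)cn2)C1`) gives 3.6, the highest of the three numbers in hand. Compound 2 (`CC(=O)N[C@@H]1CCC[C@H](C(=O)Nc2cc(-c3cnn4c3CCCC4)c(F)cn2)C1`) gives 2.9 and compound 1 (`CC(=O)N[C@@H]1CCC[C@H](C(=O)Nc2cc(-c3cnc(C)n3C(C)C)ccn2)C1`) gives 1.9, both lower than compound 3 by more than the scatter. Compound 4 (`CC(=O)N[C@@H]1CCC[C@H](C(=O)Nc2cc(-c3cnn4c3CC(C)(C)C4)c(Cl)cn2)C1`) keeps the chloro group and differs from compound 3 in one group, on an aromatic carbon opposite the ring nitrogen: a group of 10 heavy atoms (8 carbon, 2 nitrogen; one five-membered non-aromatic ring with 1 hetero atom, one five-membered aromatic ring with 2 hetero atoms) in place of a group of 10 heavy atoms (8 carbon, 2 nitrogen; one five-membered aromatic ring with 2 hetero atoms, one seven-membered non-aromatic ring with 1 hetero atom), on an aromatic carbon. The two have the same atoms, joined differently. Going by the values given here, no two measured compounds differ in one place only, so the series offers no direct guide to this change. The anchor is compound 3 at 3.6, and with the atoms unchanged, only a small downward step in this assay is expected, one that may not clear the scatter. The estimated change is a number 0.30 log units lower from compound 3 to compound 4 (within the scatter). For compound 4 the expected value is 3.3, with an estimated range of 2.9 to 3.7.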

Compound 4, distribution coefficient: 3.8
The estimate for compound 4 lay 0.50 log units below the measured number, outside the stated range (above it).
By their numbers in this assay, from the lowest: compound 1; then compound 2; then compounds 3 and 4 (each within the scatter of the next).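

Working from the chloro compounds, this assay gives the first one-place comparison in the series: a group with one five-membered non-aromatic ring in place of a group with one seven-membered non-aromatic ring, on an aromatic carbon opposite the ring nitrogen, gives a number 0.20 log units higher from compound 3 to compound 4 (within the scatter). With the chloro group kept, the same atoms joined differently therefore leave the read-out within the scatter, so these two groups cannot be told apart in this assay. No measurement in hand accounts for this step.

As far as these compounds go, it remains open how this place responds when its atoms change, for example with an amine or a carboxylic acid on the five-membered non-aromatic ring. The contribution of the chloro group is also open, as no pair shown differs there alone.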